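Swapping Methoxy for Methyl in Compound 1

A few compounds are considered here, and "the series" means these few. Any claim that something is new, unique, unknown or untested is made for them only; others in the source may bear on it.

Of the compounds shown here, two sharing one core have been measured so far. Compound 1 `COc1ccc(Nc2cc(C)nc(SCc3nc4ccccc4[nH]3)n2)cc1` gives 67400 nM in a functional assay on PC-3 cells (Homo sapiens) for cytotoxicity, read by MTT assay, with a stated time of 72 h (a higher number here means a weaker inhibitor, a lower number a stronger inhibitor), the higher of the two numbers shown, although the gap to its only neighbour lies within the scatter. Compound 2 `Cc1cc(Nc2ccc(Br)cc2)nc(SCc2nc3ccccc3[nH]2)n1` gives 37100 nM in this assay. Among the measured compounds shown here, the single measured step, a 1.8-fold lower number from compound 1 to compound 2 (0.26 log units; within the scatter), is bromo in place of methoxy on an aromatic carbon. Compound 3 `Cc1ccc(Nc2cc(C)nc(SCc3nc4ccccc4[nH]3)n2)cc1` has not yet been measured. It differs from compound 1 by methyl in place of methoxy on an aromatic carbon. For the measured compounds named here, the one measured step that bears on this change, a 1.8-fold lower number from compound 1 to compound 2 (0.26 log units; within the scatter), shows that replacing the methoxy at that aromatic carbon left the number within the scatter, so a step of about a 1.3-fold lower number from compound 1 to compound 3 (0.13 log units; within the scatter) is expected, in the same direction as the bromo step or not beyond the scatter at all. Compound 3 is therefore estimated at 50000 nM, with a likely range from 20000 nM to 130000 nM.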

Compound 3, half-maximal inhibitory concentration: 56000 nM
Estimate against measurement, compound 3: 1.1-fold (0.05 log units) below, within the range that was stated.
By their numbers in this assay, from the lowest: compounds 2, 3 and 1 (each within the scatter of the next).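

The methyl compound adds a third group at this aromatic carbon, para to a large group, and the picture stays flat: a 1.2-fold lower number from compound 1 to compound 3 (0.08 log units; within the scatter) for methyl in place of methoxy and a 1.5-fold higher number from compound 2 to compound 3 (0.18 log units; within the scatter) for methyl in place of bromo both lie within the scatter in this assay. Methoxy, bromo and methyl therefore cannot be told apart here, even though methyl has one heavy atom against two for methoxy and no hydrogen-bond acceptor against one. Nothing at hand gives a measured reason for this flat result.

Going by these compounds, whether an amine or a carboxylic acid on this same aromatic carbon would give a step beyond the scatter remains open. So does whether a longer chain in place of the methyl on the shared core would do so.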